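This account rests on a few compounds, and the source may have more. Where it says the series, first, only, none or still open, it means among the compounds named here.

Compound 1 `C[C@@H]1CCCN1c1c(C#N)c2c(N)nc(Nc3cn[nH]c3)nc2n1C` was tested in an assay on isolated protein for inhibition of Leucine-rich repeat serine/threonine-protein kinase 2 (Homo sapiens), read by TR-FRET and LanthaScreen, with stated times of 50 min and 30 min, in the presence of a further agent that is not named here (on this read-out lower numbers stand for stronger inhibition and higher numbers for weaker inhibition), and gives 6 nM. Two related compounds share its core. Compound 2 `Cc1cn(C)nc1Nc1cc2c(c(N)n1)c(C#N)c(N1CCC[C@H]1C)n2C` gives 2110 nM in this assay, and compound 3 `Cc1c(Nc2nc(N)c3c(C#N)c(N4CCC[C@H]4C)n(C)c3n2)cnn1CC1(O)COC1` gives 16 nM. Among these three numbers compound 1 has the lowest; the gap to compound 3 lies beyond the usual scatter, and the gap to compound 2 is far larger.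

Compound 4 `C[C@@H]1CCCN1c1c(C#N)c2c(N)nc(N)nc2n1C` has not yet been measured in this assay. It differs from compound 1 in one place: hydrogen in place of 1H-pyrazol-4-yl on a nitrogen on an aromatic ring. Among the compounds with values here, in every measured compound the nitrogen on the aromatic ring carries a pyrazole of some kind, so there is no direct precedent for removing it entirely. What the numbers do show is that even a change on the pyrazole itself can cost a great deal, since compound 2 gives 2110 nM where compound 1 gives 6 nM. Taking away the whole ring is expected to weaken inhibition clearly, with the step of a 67-fold higher number from compound 1 to compound 4 (1.82 log units; beyond the scatter) well beyond the scatter. Compound 4 is therefore estimated at 400 nM, in a range from 50 nM to 4000 nM.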

Compound 4, half-maximal inhibitory concentration: 248 nM
Beside the measured number, compound 4's estimate is 1.6-fold (0.21 log units) above it, and the stated range covers the measured number.
By their numbers in this assay, from the lowest: compound 1; then compound 3; then compound 4; then compound 2.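

Within the data shown here, this is the first direct reading of what the 1H-pyrazol-4-yl itself contributes: in this assay, putting hydrogen in its place on the nitrogen gives a 41-fold higher number from compound 1 to compound 4 (1.62 log units; beyond the scatter) and so counts as a large loss of inhibition. The ring is not the whole story, though, since compound 4 keeps the shared core without it and still gives 248 nM as a measurable number. No measurement at hand explains why removing the ring costs this much.

Still open, on these data alone, is whether a group much smaller than the ring, such as methyl or acetyl, would win back part of this step. Also open, as far as these compounds go, is whether a phenyl ring on the same nitrogen could do what the 1H-pyrazol-4-yl does.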